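Ethyl in Place of Bromo on the Shared Core

A few compounds are considered here, and "the series" means these few. Any claim that something is new, unique, unknown or untested is made for them only; others in the source may bear on it.

Measured compounds:
compound 1 `O=C(NO)c1ccc(NCc2nc(-c3ccc(Br)cc3)nn2-c2ccccc2)cc1` — 54.7%
compound 2 `COc1ccc(-n2nc(-c3ccc(O)cc3)nc2CNc2ccc(C(=O)NO)cc2)cc1` — 70.3%

In an assay on Sf9 cells for inhibition of protein deacetylase HDAC6 (Homo sapiens), read by fluorescence, with a stated time of 40 min, tested at 100 nM (a higher number here means more inhibition at the concentration tested (going by the name of the read-out), a lower number less inhibition), compound 1 gives 54.7%, the lower of the two numbers shown. Compound 2 gives 70.3%, a number that stands beyond the scatter above compound 1. Among the compounds with values here, no step between measured compounds that differ in one place exists here. Compound 3 `CCc1ccc(-c2nc(CNc3ccc(C(=O)NO)cc3)n(-c3ccccc3)n2)cc1` differs from compound 1 by ethyl in place of bromo on an aromatic carbon. Within the data shown here, with no measured step of this kind to rest on, the expected step is small, a number 4.7 percentage points lower from compound 1 to compound 3 (within the scatter), and none beyond the scatter. Compound 3 is estimated at 50%, within a range from 30% to 70%.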

Compound 3, a percentage reported as inhibition, at one concentration (the size of the read-out at that concentration, not a potency): 54.6%
Compound 3: middle estimate off by 4.6 percentage points, on the low side; low and high end bracket the measured number.
By their numbers in this assay, from the lowest: compounds 3 and 1 (each within the scatter of the next); then compound 2.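

In this assay, ethyl in place of bromo on the aromatic carbon gives a number 0.1 percentage points lower from compound 1 to compound 3 (within the scatter), the first step measured at this position. On the shared core, then, this place takes either group and the read-out stays within the scatter, at a single tested concentration. No evidence bearing on the reason for this result is at hand. The compounds shown leave open whether an amine, a carboxylic acid or a longer chain such as butyl at this same place would also read alike.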